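This account rests on a few compounds, and the source may have more. Where it says the series, first, only, none or still open, it means among the compounds named here.

Measured so far in a functional assay on 1321-N1 cells for agonist activity at P2Y purinoceptor 6 (Homo sapiens), read by scintillation counting and inositol phosphate accumulation; a lower number here means that less compound is needed, a higher number that more compound is needed for the effect:

- compound 1 `O=c1[nH]/c(=N\OCCCc2ccc(Br)cc2)ccn1[C@@H]1O[C@H](COP(=O)(O)OP(=O)(O)OP(=O)(O)O)[C@@H](O)[C@H]1O` gives 225 nM
- compound 2 `O=c1[nH]/c(=N\OCCCc2cccc(I)c2)ccn1[C@@H]1O[C@H](COP(=O)(O)OP(=O)(O)OP(=O)(O)O)[C@@H](O)[C@H]1O` gives 299 nM
- compound 3 `O=c1[nH]/c(=N\OCCCc2cccc([N+](=O)[O-])c2)ccn1[C@@H]1O[C@H](COP(=O)(O)OP(=O)(O)OP(=O)(O)O)[C@@H](O)[C@H]1O` gives 9700 nM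

Compound 3 stands with the highest number of the three; its nearest neighbour is compound 2, and compound 1 lies furthest from it. The two halogen-bearing compounds sit close together, as the step of a 1.3-fold higher number from compound 1 to compound 2 (0.12 log units; within the scatter) shows, whereas the nitro compound falls well away from both: a 43-fold higher number from compound 1 to compound 3 (1.63 log units; beyond the scatter) and a 32-fold higher number from compound 2 to compound 3 (1.51 log units; beyond the scatter).

Compound 4 `COc1ccc(CCCO/N=c2/ccn([C@@H]3O[C@H](COP(=O)(O)OP(=O)(O)OP(=O)(O)O)[C@@H](O)[C@H]3O)c(=O)[nH]2)cc1` is the next member. The change is 4-methoxyphenyl in place of 3-nitrophenyl on a saturated chain carbon, three bonds along the chain from an oxygen. Both measured steps that lead to compound 3 bear on it, since each replaces the 3-nitrophenyl group by another substituted phenyl and each was large, moving the number down by a wide margin. Nothing measured shows how a methoxy group itself behaves here, so the expectation is for a sizeable drop from compound 3 in this assay, but with broad uncertainty, the step being estimated as an 8.1-fold lower number from compound 3 to compound 4 (0.91 log units; beyond the scatter). Compound 4 is therefore expected near 1200 nM, in the range 300 nM to 6000 nM.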

Compound 4, half-maximal effective concentration: 277 nM
The estimate for compound 4 lay 4.3-fold (0.64 log units) above the measured number; the measured number lies below the stated range.
By their numbers in this assay, from the lowest: compounds 1, 4 and 2 (each within the scatter of the next); then compound 3.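

In this assay, 4-methoxyphenyl at this place, on a saturated chain carbon, three bonds along the chain from an oxygen, does not carry the high number of 3-nitrophenyl: a 35-fold lower number from compound 3 to compound 4 (1.54 log units; beyond the scatter). Methoxy in place of bromo gives a 1.2-fold higher number from compound 1 to compound 4 (0.09 log units; within the scatter), and 4-methoxyphenyl in place of 3-iodophenyl gives a 1.1-fold lower number from compound 2 to compound 4 (0.03 log units; within the scatter), so among the four compounds a non-halogen substituent reads like the two halogens, and compound 3 alone goes against this. No measurement at hand accounts for the separate standing of compound 3.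

Whether that standing belongs to the nitro group or to its ring position stays open, as neither 4-nitrophenyl nor 3-methoxyphenyl is among the compounds shown. Also open, as far as these compounds go, is how an amine or a carboxylic acid on the phenyl ring, or a longer chain, would read in this assay.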